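Swapping pyridin-3-yl for (methylsulfanyl)methyl in compound 3

A few compounds are considered here, and "the series" means these few. Any claim that something is new, unique, unknown or untested is made for them only; others in the source may bear on it.

Measured in a functional assay with Oryctolagus cuniculus as the target; on this read-out higher numbers stand for weaker inhibition and lower numbers for stronger inhibition:
Compound 1 `CNC(=N)Nc1nc(-c2ccc(OC)cc2)c(-c2ccc(OC)cc2)s1`: 62 nM
Compound 2 `COc1ccc(-c2nc(/N=C(\N)N(C)C)sc2-c2ccc(OC)cc2)cc1`: 37 nM
Compound 3 `COc1ccc(-c2nc(CNC(=O)c3cccnc3)sc2-c2ccc(OC)cc2)cc1`: 25 nM

Compound 3, at 25 nM, separates clearly on one side only: a 2.5-fold lower number from compound 1 to compound 3 (0.39 log units; beyond the scatter), whereas a 1.5-fold lower number from compound 2 to compound 3 (0.17 log units; within the scatter). Compound 4 `COc1ccc(-c2nc(CNC(=O)CSC)sc2-c2ccc(OC)cc2)cc1` carries (methylsulfanyl)methyl in place of pyridin-3-yl on a carbonyl carbon. Among the compounds with values here, no measured step changes this group alone. The two steps above replace a larger group on an aromatic carbon, and both are small, so they bear only indirectly. In this assay, no step beyond the scatter is therefore expected, and the data fix no firm direction. The expected change is a 1.4-fold higher number from compound 3 to compound 4 (0.15 log units; within the scatter). Compound 4 is estimated at 35 nM, with an expected range from 11 nM to 110 nM.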

Compound 4, half-maximal inhibitory concentration: < 100 nM
Compound 4 gave a limit, no number; the forecaster's own chance of this, stated with the estimate: 3%; the middle value does not contradict the limit.
By their numbers in this assay, from the lowest: compounds 3, 2 and 1 (each within the scatter of the next, the first and the last beyond it).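

Compound 4 gave < 100 nM which is a limit and not a number, so its steps from compound 1, compound 2 and compound 3 cannot be read. The compounds shown leave open whether (methylsulfanyl)methyl in place of pyridin-3-yl on a carbonyl carbon changes the number at all, and in which direction.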